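Swapping a Fused Bicyclic Thioether for a Single Chlorine

The compounds below may be only part of what the source reports. "The series", "measured", "known", "first", "only" and "open" are said of these compounds alone.

Compound 2 `C=C1C2=C(C(=O)N1OC)[C@H](OC(=O)CSc1nc3ccccc3[nH]1)[C@@](C)(O)[C@H](CCCCC)O2` is the weaker of the two compounds measured in a functional assay on THP-1 cells (Homo sapiens) for cytotoxicity, read by MTT assay, with a stated time of 72 h (a lower number here means a stronger inhibitor, a higher number a weaker inhibitor), where compound 2 gives 5300 nM. Its nearest neighbour is compound 1 `C=C1C2=C(C(=O)N1OC)[C@H](OC(=O)CSc1nc3ccccc3s1)[C@@](C)(O)[C@H](CCCCC)O2`, which in this assay gives 1600 nM; the step of a 3.3-fold higher number from compound 1 to compound 2 (0.52 log units; beyond the scatter) separates them. Compound 3 `C=C1C2=C(C(=O)N1OC)[C@H](OC(=O)CCl)[C@@](C)(O)[C@H](CCCCC)O2` has not yet been measured. It differs from compound 2 by chloro in place of (1H-benzimidazol-2-yl)sulfanyl on a saturated chain carbon bound to a carbonyl carbon. Among the compounds with values here, the single measured step concerns an exchange of one fused bicyclic ring for another on the sulfur, not the removal of the whole (1H-benzimidazol-2-yl)sulfanyl group, so no recorded step bears directly on this change, and its direction cannot be read from the data. The estimate therefore stays near the value of compound 2, with a wide range on either side. Compound 3 is expected to give about 2500 nM in this assay, between 500 nM and 12000 nM, a step of a 2.1-fold lower number from compound 2 to compound 3 (0.33 log units; beyond the scatter) that is only an expectation.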

Compound 3, half-maximal inhibitory concentration: 11000 nM
Compound 3: middle estimate off by 4.4-fold (0.64 log units), on the low side, and the stated range covers the measured number.
By their numbers in this assay, from the lowest: compound 1; then compound 2; then compound 3.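

In this assay the change to chloro brings a 2.1-fold higher number from compound 2 to compound 3 (0.32 log units; beyond the scatter) when (1H-benzimidazol-2-yl)sulfanyl leaves and a 6.9-fold higher number from compound 1 to compound 3 (0.84 log units; beyond the scatter) when (1,3-benzothiazol-2-yl)sulfanyl leaves, so both sulfur-linked ring groups give stronger results than the lone chloro at this place. The shared core still gives a measurable cytotoxic effect with only chloro on this saturated chain carbon, which means the ring-bearing groups strengthen the result but are not required for it. Nothing measured here speaks to the cause of this difference.

The compounds shown leave open whether the gain comes from the fused rings, from the sulfur or simply from a larger group. A phenylsulfanyl group, with a single ring on the sulfur, or an amine at this place could help separate these possibilities.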